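The compounds below may be only part of what the source reports. "The series", "measured", "known", "first", "only" and "open" are said of these compounds alone.

Compound 2 `NC(=O)c1c(NC(=O)c2ccccc2Cl)sc2c1CCN(C(=S)Nc1ccccc1Br)C2` is the starting point. In a functional assay on HeLa cells (Homo sapiens) for antiproliferative activity, with a stated time of 24 h (on this read-out higher numbers stand for weaker inhibition and lower numbers for stronger inhibition), compound 2 gives 24600 nM. Only two numbers are shown in this assay; the other belongs to compound 3 `NC(=O)c1c(NC(=O)c2ccccc2Cl)sc2c1CCN(C(=S)Nc1ccccc1-c1ccccc1)C2`, which gives 24000 nM, so that the step from compound 2 to compound 3 is a 1.0-fold lower number from compound 2 to compound 3 (0.01 log units; within the scatter). Compound 1 `N#Cc1ccccc1CN1CCc2c(sc(NC(=O)c3ccccc3Cl)c2C(N)=O)C1` yields only a limit in this assay, namely > 50000 nM, which is the limit described as the limit of > 50000 nM in this assay, at which 1 of the 3 values shown sits.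

The change to compound 4 `NC(=O)c1c(NC(=O)c2ccccc2Br)sc2c1CCN(C(=S)Nc1ccccc1Br)C2` is bromo in place of chloro on an aromatic carbon. Of the two measured steps, an at least 2.0-fold lower number from compound 1 to compound 2 (0.30 log units; that floor lies within the scatter) replaces the whole substituent on the ring amine nitrogen, and a 1.0-fold lower number from compound 2 to compound 3 (0.01 log units; within the scatter) swaps bromo for phenyl on that same substituent; neither touches the benzamide ring where the present exchange sits, and neither moved the number beyond the scatter. A swap of one halogen for another of the same family on an aromatic carbon is a smaller change than either of those, so no step beyond the scatter is expected in this assay, in either direction.

Compound 4 is therefore expected to give about 24000 nM in this assay, between 12000 nM and 50000 nM, meaning an expected step of a 1.0-fold lower number from compound 2 to compound 4 (0.01 log units; within the scatter).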

Compound 4, half-maximal inhibitory concentration: 24700 nM
Estimate against measurement, compound 4: 1.0-fold (0.01 log units) below; the range from low to high includes it.
By their numbers in this assay, from the lowest: compounds 3, 2 and 4 (each within the scatter of the next). At a limit, above all of these: compound 1.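

The step from 2-chlorophenyl to 2-bromophenyl is the only change shown at this place, on an aromatic carbon of a six-membered aromatic ring of carbon only, ortho to a large group, and in this assay it amounts to a 1.0-fold higher number from compound 2 to compound 4 (0.00 log units; within the scatter). The earlier steps shown here all lay in the substituent on the ring amine nitrogen, so this result adds a second place in the molecule, and at this place chloro and bromo cannot be told apart on this read-out, at least with the rest of compound 2 held fixed. Nothing among the measurements shown gives a reason for this result or bears on it directly.

For the compounds shown here, it remains open whether a group of another kind at this place, such as an amine, a methoxy group or a carboxylic acid, would move the number beyond the scatter, since chloro and bromo are the only two groups compared here. From the compounds shown here alone, it is also open whether the exchange of chloro for bromo would read the same with the phenyl of compound 3 in place of the bromo on the other substituent.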